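Methoxy in Place of Chloro on the Aryl Ring of Compound 3

A few compounds are considered here, and "the series" means these few. Any claim that something is new, unique, unknown or untested is made for them only; others in the source may bear on it.

Compound 3 `CC1=C(/C=C/C(=O)/C=C/c2ccccc2Cl)C(C)(C)CCC1` gives 21800 nM in a functional assay on HeLa cells (Homo sapiens) for cytotoxicity, read by sulforhodamine B assay, with a stated time of 48 h (a higher number here means a weaker inhibitor, a lower number a stronger inhibitor), the lowest of the three numbers shown; compound 2 `CC1=C(/C=C/C(=O)/C=C/c2ccc(F)cc2)C(C)(C)CCC1`, at 32200 nM, stands within the scatter of it, while compound 1 `CC1=C(/C=C/C(=O)/C=C/c2ccccc2)C(C)(C)CCC1`, at 70200 nM, lies further off. Compound 4 `COc1ccccc1/C=C/C(=O)/C=C/C1=C(C)CCCC1(C)C` differs from compound 3 in one place: methoxy in place of chloro on an aromatic carbon. For the measured compounds named here, no measured step exchanges a chloro for a methoxy. Going by the values given here, the steps that bear on it show what a fluoro or chloro adds to the unsubstituted ring: a 3.2-fold lower number from compound 1 to compound 3 (0.51 log units; beyond the scatter) and a 2.2-fold lower number from compound 1 to compound 2 (0.34 log units; beyond the scatter); a 1.5-fold lower number from compound 2 to compound 3 (0.17 log units; within the scatter) separates the two. Among the compounds with values here, removing the chloro is therefore expected to give back part of that gain, and the methoxy has no precedent here, so a modest rise, a 1.7-fold higher number from compound 3 to compound 4 (0.24 log units; within the scatter), is expected. Compound 4 is estimated at 38000 nM, with a range from 13000 nM to 110000 nM.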

Compound 4, half-maximal inhibitory concentration: 88200 nM
The estimate for compound 4 lay 2.3-fold (0.37 log units) below the measured number; the range from low to high includes it.
By their numbers in this assay, from the lowest: compounds 3 and 2 (each within the scatter of the next); then compounds 1 and 4 (each within the scatter of the next).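

In this assay, the aromatic carbon ortho to a large group proves sensitive to what it carries: methoxy in place of chloro gives a 4.0-fold higher number from compound 3 to compound 4 (0.61 log units; beyond the scatter) and so does not keep what chloro gained. Methoxy in place of hydrogen gives a 1.3-fold higher number from compound 1 to compound 4 (0.10 log units; within the scatter) and so cannot be told apart from the unsubstituted ring. Nothing available explains the difference between chloro and methoxy. On these data alone, whether an amine or an ethoxy group at this place would stand nearer compound 3 or compound 1 remains open.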